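The compounds below may be only part of what the source reports. "The series", "measured", "known", "first", "only" and "open" are said of these compounds alone.

Compound 1 `COc1ccccc1-c1cn(C[C@H](O)[C@H]2OC(=O)C(OCc3ccccc3)=C2OCc2ccccc2)nn1`: in a functional assay on HeLa cells (Homo sapiens) for antiproliferative activity, read by MTT assay, with a stated time of 72 h (on this read-out lower numbers stand for stronger inhibition and higher numbers for weaker inhibition), compound 1 gives > 100000 nM, which is a limit of the assay rather than a number.
Compound 2 `Cc1ccc(-c2cn(C[C@H](O)[C@H]3OC(=O)C(OCc4ccccc4)=C3OCc3ccccc3)nn2)cc1`: compound 2 gives 25500 nM.
Compound 3 `O=C1O[C@H]([C@@H](O)Cn2cc(CCCCl)nn2)C(OCc2ccccc2)=C1OCc1ccccc1`: compound 3 gives 36700 nM.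

Compound 3 holds the highest of the two numbers shown, but its nearest neighbour, compound 2, sits a 1.4-fold higher number from compound 2 to compound 3 (0.16 log units; within the scatter), so the two cannot be told apart. The unmeasured compound 4 `CCCCCCCCCCc1cn(C[C@H](O)[C@H]2OC(=O)C(OCc3ccccc3)=C2OCc2ccccc2)nn1` differs from compound 3 by heptyl in place of chloro on a saturated chain carbon, three bonds along the chain from an aromatic carbon. Among the compounds with values here, no measured step lengthens a chain in this way; the only steps that touch this part of the core swap an aromatic group for a chain, and of those an at least 2.7-fold lower number from compound 1 to compound 3 (0.43 log units; beyond the scatter) runs against a limit while a 1.4-fold higher number from compound 2 to compound 3 (0.16 log units; within the scatter) stays within the scatter. Within the data shown here, with no step to lean on, a change within the scatter is expected for compound 4, a 1.5-fold lower number from compound 3 to compound 4 (0.17 log units; within the scatter). The estimate for compound 4 in this assay is therefore 25000 nM, expected between 6000 nM and 90000 nM.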

Compound 4, half-maximal inhibitory concentration: 22900 nM
For compound 4 the middle estimate is 1.1-fold (0.04 log units) above the measured one, and the stated range covers the measured number.
By their numbers in this assay, from the lowest: compounds 4, 2 and 3 (each within the scatter of the next). At a limit, above all of these: compound 1.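

In this assay, heptyl in place of chloro stays within the scatter, a 1.6-fold lower number from compound 3 to compound 4 (0.20 log units; within the scatter), so this position takes the longer decyl chain with no change that can be read. Decyl in place of 4-methylphenyl also stays within the scatter, a 1.1-fold lower number from compound 2 to compound 4 (0.05 log units; within the scatter), so at this position the chain and that aromatic group cannot be told apart. Only compound 1 stands apart, an at least 4.3-fold lower number from compound 1 to compound 4 (0.64 log units; beyond the scatter), and that step rests on a limit: the limit of > 100000 nM in this assay, at which 1 of the 4 values shown sits.

The compounds shown leave open whether an amine or a carboxylic acid in place of chloro would move the number beyond the scatter.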